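This account rests on a few compounds, and the source may have more. Where it says the series, first, only, none or still open, it means among the compounds named here.

Measured so far in a functional assay on CAKI-1 cells (Homo sapiens) for inhibition; on this read-out lower numbers stand for stronger inhibition of growth and higher numbers for weaker inhibition of growth:
- compound 1 `O=C(/C=C/c1cccc(O)c1)c1cccc(-n2cc(-c3ccccc3)[nH]c2=O)c1`, which gives 13300 nM
- compound 2 `O=C(/C=C/c1cccc(O)c1)c1cccc(-n2cc(-c3ccc(Cl)cc3)[nH]c2=O)c1`, which gives 1720 nM

Going by the values given here, compound 2 stands at the lowest of the two numbers recorded in this assay, and the only single-point step measured, a 7.7-fold lower number from compound 1 to compound 2 (0.89 log units; beyond the scatter), took it there through a chloro in place of hydrogen on an aromatic carbon of the phenyl group attached to the shared core.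

Compound 3 `COc1cc(/C=C/C(=O)c2cccc(-n3cc(-c4ccc(Cl)cc4)[nH]c3=O)c2)ccc1O` differs from compound 2 in another place: 4-hydroxy-3-methoxyphenyl in place of 3-hydroxyphenyl on a double-bonded chain carbon bound to a double-bonded chain carbon. Among the compounds with values here, the measured step from compound 1 to compound 2 concerns the phenyl ring on the other side of the core and says nothing about the hydroxyphenyl end of the chain, so no recorded step bears directly on this change. Within the data shown here, with no comparable precedent, the expectation for compound 3 is a step of about a 1.0-fold lower number from compound 2 to compound 3 (0.01 log units; within the scatter) in this assay, that is, nothing clearly beyond the usual scatter in either direction, with a wide band of uncertainty. Compound 3 is therefore estimated to give about 1700 nM in this assay, most likely between 500 nM and 6000 nM.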

Compound 3, concentration for 50% growth inhibition: 2640 nM
Compound 3: middle estimate off by 1.6-fold (0.19 log units), on the low side; low and high end bracket the measured number.
By their numbers in this assay, from the lowest: compounds 2 and 3 (each within the scatter of the next); then compound 1.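

In this assay, the hydroxyphenyl end of the chain now has a measured step of its own: 4-hydroxy-3-methoxyphenyl in place of 3-hydroxyphenyl on a double-bonded chain carbon bound to a double-bonded chain carbon gives a 1.5-fold higher number from compound 2 to compound 3 (0.19 log units; within the scatter), so compound 2 and compound 3 cannot be told apart on this read-out. This position therefore accepts a group of 9 heavy atoms in place of one of 7, with the hydrogen-bond donor count unchanged and one more acceptor, without a change that stands clear of the scatter, unlike the chloro exchange on the other side of the core, which gave a 7.7-fold lower number from compound 1 to compound 2 (0.89 log units; beyond the scatter). Nothing on hand accounts for this result.

The exchange alters the place of the hydroxy group and adds a methoxy group in a single step, so the compounds shown do not separate these two changes or say whether the same exchange would behave alike without the chloro group. They also leave open how an amine or a carboxylic acid on this ring would read in this assay.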